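Double-bond configuration on the secondary amine

The source may hold more compounds than are shown below. What is called first, only, known or untested is meant among the compounds shown, and "the series" means these compounds.

Compound 1 `CN(C)CC/C=C(\c1ccc(Br)cc1)c1cccnc1`: 7100 nM
Compound 2 `CN(C)CC/C=C(/c1ccc(Br)cc1)c1cccnc1`: 900 nM
Compound 3 `CNCC/C=C(\c1ccc(Br)cc1)c1cccnc1`: 120 nM

In a functional assay (brain) for inhibition, with Mus musculus as the target (on this read-out higher numbers stand for weaker inhibition and lower numbers for stronger inhibition), compound 3 has the lowest number of the three, at 120 nM. Compound 4 `CNCC/C=C(/c1ccc(Br)cc1)c1cccnc1` changes one thing: the two compounds have the same atoms and bonds and differ only in configuration as drawn: 1 of 1 stereo elements differ; a double bond is drawn E in compound 3 and Z in compound 4. The same change has been measured once, as a 7.9-fold lower number from compound 1 to compound 2 (0.90 log units; beyond the scatter), a modest step, given (the fact that compounds 1 and 2 differ only in the configuration as drawn). The other measured step, a 59-fold lower number from compound 1 to compound 3 (1.77 log units; beyond the scatter), is large, but it concerns the amine nitrogen and bears only on the starting point. With a single precedent, a drop in the same direction and of similar or slightly smaller size is expected. The expected step is a 6.0-fold lower number from compound 3 to compound 4 (0.78 log units; beyond the scatter). Compound 4 is therefore estimated at 20 nM, within a range of 5 nM to 100 nM.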

Compound 4, half-maximal inhibitory concentration: 500 nM
Compound 4: the middle estimate sits 25-fold (1.40 log units) below what was measured, outside the stated range (above it).
By their numbers in this assay, from the lowest: compound 3; then compounds 4 and 2 (each within the scatter of the next); then compound 1.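

In this assay, the double-bond change runs opposite ways on the two amines: a 4.2-fold higher number from compound 3 to compound 4 (0.62 log units; beyond the scatter), against a 7.9-fold lower number from compound 1 to compound 2 (0.90 log units; beyond the scatter) with the extra methyl present. Hydrogen in place of methyl on an amine nitrogen gives only a 1.8-fold lower number from compound 2 to compound 4 (0.26 log units; within the scatter) in the Z series, so the size of that step depends on the double-bond configuration: the same change on two cores in this assay, a 59-fold lower number (1.77 log units; beyond the scatter) from compound 1 to compound 3 and a 1.8-fold lower number (0.26 log units; within the scatter) from compound 2 to compound 4, 33-fold (1.52 log units) apart, beyond the scatter of two such steps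

The compounds shown leave open whether the reversal also holds for a primary amine or for an ethyl group on the amine nitrogen. They also do not show why the two configurations respond differently.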